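Nitrofuran Ester Replaces Sulfonylcarbamate on a Triterpenoid Core

A few compounds are considered here, and "the series" means these few. Any claim that something is new, unique, unknown or untested is made for them only; others in the source may bear on it.

Compound 1, `CC1=CC[C@H]2[C@@H]1CC=C(C)[C@@H](CC[C@H]1[C@]3(C)CC[C@H](OC(=O)c4ccncc4)C(C)(C)O[C@H]3CC[C@@]1(C)O)C2(C)C`: > 50000 nM
Compound 2, `CC1=CC[C@H]2[C@H](CC[C@]2(C)O)C(C)(C)[C@@H]1CC[C@H]1[C@]2(C)CC[C@H](OC(=O)NS(=O)(=O)c3ccc(C)cc3)C(C)(C)O[C@H]2CC[C@@]1(C)O`: > 50000 nM

In a functional assay on MCF7 cells (Homo sapiens) for antiproliferative activity, read by MTT assay, with a stated time of 72 h (on this read-out lower numbers stand for stronger inhibition and higher numbers for weaker inhibition), compound 1 gives > 50000 nM, which is a limit of the assay rather than a number. Compound 2 likewise reaches only a limit, > 50000 nM. Within the data shown here, both measured values sit at the limit of > 50000 nM in this assay, at which 2 of the 2 values shown sit, so no step between measured compounds can be read. Compound 3, `CC1=CC[C@H]2[C@H](CC[C@]2(C)O)C(C)(C)[C@@H]1CC[C@H]1[C@]2(C)CC[C@H](OC(=O)c3ccc([N+](=O)[O-])o3)C(C)(C)O[C@H]2CC[C@@]1(C)O`, differs from compound 2 by 5-nitrofuran-2-yl in place of ((4-methylphenyl)sulfonyl)amino on a carbonyl carbon. Among the measured compounds shown here, no measured step guides this change; the expectation is that the step of an at least 1.2-fold lower number from compound 2 to compound 3 (0.09 log units; that floor lies within the scatter) brings at most a gain not clearly beyond the usual scatter. Compound 3 is therefore expected to give about 40000 nM, between 8000 nM and 50000 nM.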

Compound 3, half-maximal inhibitory concentration: 21300 nM
Beside the measured number, compound 3's estimate is 1.9-fold (0.27 log units) above it; measured number inside the range.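

In this assay, among these compounds, the group on this carbonyl carbon does affect the read-out: 5-nitrofuran-2-yl in place of ((4-methylphenyl)sulfonyl)amino gives an at least 2.3-fold lower number from compound 2 to compound 3 (0.37 log units; beyond the scatter) and yields the first actual number in this set. That step is only a minimum, because compound 2 reaches a limit of the assay rather than a number: the limit of > 50000 nM in this assay, at which 2 of the 3 values shown sit.

On these data alone, whether the activity needs the nitro group stays open, and a plain furan-2-yl would test that. As far as these compounds go, how an amine or a carboxylic acid would behave on this carbonyl carbon also remains unknown.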